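This account rests on a few compounds, and the source may have more. Where it says the series, first, only, none or still open, it means among the compounds named here.

Working notes on the series. Compound 1 `O=C(CCC1CCCC1)N(O)c1ccc(Cl)cc1`, compound 2 `O=C(C1CCCCC1)N(O)c1ccc(Cl)cc1` and compound 3 `O=C(CC1CCCCC1)N(O)c1ccc(Cl)cc1` share one core and differ only in the group on the saturated chain carbon bound to the carbonyl carbon. In a functional assay on L1210 cells (Homo sapiens) for inhibition, with L1210 (Mus musculus) as the target (a higher number here means a weaker inhibitor, a lower number a stronger inhibitor), compound 1 gives 38000 nM, compound 2 gives 16000 nM and compound 3 gives 26000 nM. Among the measured compounds shown here, the single one-place step among them, a 1.5-fold lower number from compound 1 to compound 3 (0.16 log units; within the scatter), lies within the scatter, and compound 2 and compound 3 also sit within the scatter of each other. Compound 3 stands second highest of the three numbers, nearest compound 1 and furthest from compound 2, both gaps within the scatter.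

Compound 4 `O=C(CC1CCCCC1)N(O)c1ccccc1` differs from compound 3 by hydrogen in place of chloro on an aromatic carbon. For the measured compounds named here, no measured step touches the aromatic ring: the only measured step, from compound 1 to compound 3, alters the other end of the molecule and was itself within the scatter, so nothing measured bears directly on this change. Going by the values given here, with no bearing step, no movement beyond the scatter is expected for compound 4 in this assay, and the range is kept wide. Compound 4 is estimated at 40000 nM, with a range from 15000 nM to 110000 nM. The expected step is a 1.5-fold higher number from compound 3 to compound 4 (0.19 log units; within the scatter).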

Compound 4, half-maximal inhibitory concentration: 27000 nM
Estimate against measurement, compound 4: 1.5-fold (0.17 log units) above; measured number inside the range.
By their numbers in this assay, from the lowest: compounds 2, 3, 4 and 1 (each within the scatter of the next, the first and the last beyond it).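

In this assay, among the compounds shown here, the first change at the aromatic ring (a 1.0-fold higher number from compound 3 to compound 4 (0.02 log units; within the scatter)) lies within the scatter, so chloro and hydrogen on this aromatic carbon, para to a large group, cannot be told apart on the core of compound 3. The earlier compounds shown here varied only the group on the saturated chain carbon, and this pair shows that a change at the aromatic end can also leave the number within the scatter, although one pair sets no pattern. No measured information on hand accounts for this result.

The compounds shown leave open whether another group on this aromatic carbon, such as methoxy, nitro or an amine, would move the number beyond the scatter. Also open, from the compounds shown here alone, is whether replacing chloro with hydrogen reads the same with the side chains of compound 1 and compound 2.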